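The source may hold more compounds than are shown below. What is called first, only, known or untested is meant among the compounds shown, and "the series" means these compounds.

Working notes on the series.

Compound 1 `CCC(=O)NCc1cncc(N2C(=O)c3ccc(Cl)cc3C2(C)C)c1` gives 282 nM in an assay on cells for inhibition of cytochrome P450 11B2, mitochondrial (Homo sapiens), read by HTRF; a higher number here means a weaker inhibitor, a lower number a stronger inhibitor. Compound 3 `CC1(C)c2cc(Cl)ccc2C(=O)N1c1cncc(CNS(C)(=O)=O)c1` carries methylsulfonyl in place of propanoyl on an amine nitrogen, the change (methylsulfonyl in place of propanoyl on an amine nitrogen); in this assay compound 3 gives 33 nM, and the step is an 8.5-fold lower number from compound 1 to compound 3 (0.93 log units; beyond the scatter). Compound 2 `CCC(=O)N[C@@H]1CCCc2c1cncc2N1Cc2cc(Cl)ccc2C1=O` sits on a different core; the difference between the two cores is not broken down here. In this assay compound 2 gives 28 nM, which is within the scatter of compound 3 and well apart from compound 1.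

Compound 4 `CS(=O)(=O)N[C@@H]1CCCc2c1cncc2N1Cc2cc(Cl)ccc2C1=O` is not yet measured. It differs from compound 2 by methylsulfonyl in place of propanoyl on an amine nitrogen. This is the same kind of change as from compound 1 to compound 3, but the place differs: there the amine nitrogen's other neighbour is a saturated chain carbon, here a saturated ring carbon. The expected step of a 3.5-fold lower number from compound 2 to compound 4 (0.54 log units; beyond the scatter) is taken as smaller than the earlier one, because an 8.5-fold lower number from compound 1 to compound 3 (0.93 log units; beyond the scatter) came from the weaker compound 1, while compound 2 already gives 28 nM. Compound 4 is expected to give about 8 nM in this assay, estimated between 2.5 nM and 25 nM.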

Compound 4, half-maximal inhibitory concentration: 998 nM
Estimate against measurement, compound 4: 120-fold (2.10 log units) below, outside the stated range (above it).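

In this assay, methylsulfonyl in place of propanoyl on an amine nitrogen does not carry over from the core of compound 1 to the core of compound 2: the new step is a 36-fold higher number from compound 2 to compound 4 (1.55 log units; beyond the scatter), and it runs against the earlier one: the same change on two cores in this assay, an 8.5-fold lower number (0.93 log units; beyond the scatter) from compound 1 to compound 3 and a 36-fold higher number (1.55 log units; beyond the scatter) from compound 2 to compound 4, 300-fold (2.48 log units) apart, beyond the scatter of two such steps

In this series, then, the outcome of this change depends on the core that carries it, so a step read on one core gives no safe estimate for the other. These two pairs do not show which difference between the cores goes with the reversal, whether the saturated chain carbon or saturated ring carbon on the amine nitrogen or another part of the core, and they give no reason for it.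

Going by these compounds, it remains open whether acetyl or ethylsulfonyl in place of propanoyl on this amine nitrogen of the core of compound 2 would stay close to compound 2 or fall towards compound 4. On these data alone, it also remains open how the same change would behave on any third core.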